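Notes on the step from compound 2 to compound 4

A few compounds are considered here, and "the series" means these few. Any claim that something is new, unique, unknown or untested is made for them only; others in the source may bear on it.

- compound 1 `COc1ccc(/C=C\c2cc(OC)c(OC)c(OC)c2)cc1OCc1ccc(C=O)cc1`: 41000 nM
- compound 2 `COc1ccc(/C=C\c2cc(OC)c(OC)c(OC)c2)cc1OCc1ccc(CNCCO)cc1`: 39000 nM
- compound 3 `COc1ccc(/C=C\c2cc(OC)c(OC)c(OC)c2)cc1OCc1ccc(CN2CCCCC2C(=O)NCCNC(=O)OC(C)(C)C)cc1`: 28000 nM

All three values come from an ADME assay on NCM460 cells (Homo sapiens) for cytotoxicity, read by CCK-8 assay, with a stated time of 48 h; a lower number here means a stronger inhibitor, a higher number a weaker inhibitor. Compound 2, at 39000 nM, lies within the scatter of both compound 1 and compound 3, so it stands apart from neither. Compound 4 `COc1ccc(/C=C\c2cc(OC)c(OC)c(OC)c2)cc1OCc1ccc(CN2CC[C@@H](O)C2)cc1` is still unmeasured. Its change from compound 2 is 3-hydroxypyrrolidin-1-yl in place of (2-hydroxyethyl)amino on a saturated chain carbon bound to an aromatic carbon. Among the measured compounds shown here, the only measured step at this place is a 1.1-fold lower number from compound 1 to compound 2 (0.02 log units; within the scatter), where ((2-hydroxyethyl)amino)methyl replaced formyl. For the measured compounds named here, with that step as the sole guide, no change beyond the scatter is expected in this assay, and no direction is favoured. The expected step is a 1.1-fold lower number from compound 2 to compound 4 (0.03 log units; within the scatter). For compound 4 the estimate is 36000 nM, with an expected range of 19000 nM to 65000 nM.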

Compound 4, half-maximal inhibitory concentration: 53000 nM
The estimate for compound 4 lay 1.5-fold (0.17 log units) below the measured number; the measured number falls inside the stated range.
By their numbers in this assay, from the lowest: compounds 3, 2, 1 and 4 (each within the scatter of the next).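

In this assay the ring of 3-hydroxypyrrolidin-1-yl in place of the open (2-hydroxyethyl)amino chain gives a 1.4-fold higher number from compound 2 to compound 4 (0.13 log units; within the scatter) and so leaves the number where the open chain had it. Against the formyl starting point, (3-hydroxypyrrolidin-1-yl)methyl gives a 1.3-fold higher number from compound 1 to compound 4 (0.11 log units; within the scatter) and so also stands apart from neither group at this place. Nothing available explains these small steps.

Still open, as far as these compounds go, is whether a carboxylic acid or a longer chain in place of 3-hydroxypyrrolidin-1-yl would move the number beyond the scatter. From the compounds shown here alone, the opposite configuration at the defined stereocentre also remains open.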